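A few compounds are considered here, and "the series" means these few. Any claim that something is new, unique, unknown or untested is made for them only; others in the source may bear on it.

Compound 1 `CC(C)N(C)c1ccc2cc(NC(=O)CCc3ccc(C(F)(F)F)cc3)ccc2n1` gives 140 nM in a functional assay on HEK293 cells for activation of melanin-concentrating hormone receptor 1 (Rattus norvegicus), read by inositol phosphate accumulation; a higher number here means that more compound is needed for the effect, a lower number that less compound is needed.
Compound 2 `CN(C)c1ccc2cc(NC(=O)CCc3ccc(C(F)(F)F)cc3)ccc2n1` gives 110 nM in this assay.
Compound 3 `O=C(CCc1ccc(C(F)(F)F)cc1)Nc1ccc2nc(N3CCCCCC3)ccc2c1` gives 1800 nM in this assay.

Compound 3 has the highest number of the three measured compounds. Compound 4 `O=C(CCc1ccc(C(F)(F)F)cc1)Nc1ccc2nc(N3CCCCC3)ccc2c1` differs from it by piperidin-1-yl in place of azepan-1-yl on an aromatic carbon. The measured steps that bear on this change are a 13-fold higher number from compound 1 to compound 3 (1.11 log units; beyond the scatter) and a 16-fold higher number from compound 2 to compound 3 (1.21 log units; beyond the scatter); both are large, and both show the seven-membered ring amine giving the highest number, while the acyclic amines of compound 1 and compound 2 lie close to each other. Compound 4 keeps a ring amine but with one ring atom fewer, so a step of a 2.6-fold lower number from compound 3 to compound 4 (0.41 log units; beyond the scatter) is expected, toward a lower number but not as far as compound 1 or compound 2. Compound 4 is therefore estimated at 700 nM in this assay, with a range from 250 nM to 2500 nM.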

Compound 4, half-maximal effective concentration: 110 nM
Compound 4: middle estimate off by 6.4-fold (0.80 log units), on the high side, outside the stated range (below it).
By their numbers in this assay, from the lowest: compounds 2, 4 and 1 (each within the scatter of the next); then compound 3.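

In this assay the high number of compound 3 belongs to the seven-membered ring and not to ring amines as such among these compounds: piperidin-1-yl in place of azepan-1-yl gives a large step (a 16-fold lower number from compound 3 to compound 4 (1.21 log units; beyond the scatter)). The six-membered ring amine cannot be told apart from either acyclic amine (no change at the digits printed from compound 2 to compound 4 (within the scatter)) and (a 1.3-fold lower number from compound 1 to compound 4 (0.10 log units; within the scatter)). Nothing measured here explains why the seven-membered ring stands apart.

From the compounds shown here alone, whether a pyrrolidin-1-yl or a morpholin-4-yl at this place would stay level with compound 4 remains open.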